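A few compounds are considered here, and "the series" means these few. Any claim that something is new, unique, unknown or untested is made for them only; others in the source may bear on it.

Of the compounds shown here, three that share the same acetylpiperidine amide have been measured in an assay for displacement of a labelled ligand from DNA repair protein REV1 (Homo sapiens), read by fluorescence polarization, with a stated time of 1 h; on this read-out lower numbers stand for tighter binding and higher numbers for weaker binding. Compound 1, `CC(=O)N1CCC(C(=O)Nc2sc3c(c2C(=O)NC2CC2)CCC(C)C3)CC1`, gives 4400 nM. Compound 2, `CCCC1CCc2c(sc(NC(=O)C3CCN(C(C)=O)CC3)c2C(N)=O)C1`, gives 9500 nM. Compound 3, `CCCc1cc(C(=O)OCC)c(NC(=O)C2CCN(C(C)=O)CC2)s1`, gives 7800 nM. On these numbers compound 2 stands highest; its gap to compound 3 is within the usual scatter, so the two cannot be told apart, while compound 1 sits clearly lower than compound 2, that is, it binds more tightly.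

Compound 4, `CC(=O)N1CCC(C(=O)Nc2sc3c(c2C(N)=O)CCC(C)C3)CC1`, differs from compound 2 in one place: hydrogen in place of ethyl on a saturated chain carbon bound to a saturated ring carbon. Among the measured compounds shown here, no directly comparable pair among the measured compounds shows what such a trimming of the chain does here; compound 1 carries the shorter chain but also a different amide, so it is not a clean guide. The expectation is therefore a modest step, if any, from compound 2 to compound 4 in this assay, written as a 1.4-fold lower number from compound 2 to compound 4 (0.13 log units; within the scatter), possibly toward a slightly lower number but not beyond the scatter. Compound 4 is estimated at 7000 nM, with a range from 3000 nM to 16000 nM.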

Compound 4, dissociation constant: 12600 nM
Estimate against measurement, compound 4: 1.8-fold (0.26 log units) below; the measured number falls inside the stated range.
By their numbers in this assay, from the lowest: compounds 1, 3, 2 and 4 (each within the scatter of the next, the first and the last beyond it).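

In this assay, hydrogen in place of ethyl on a saturated chain carbon bound to a saturated ring carbon, which amounts to propyl to methyl, gives a 1.3-fold higher number from compound 2 to compound 4 (0.12 log units; within the scatter) and so leaves binding indistinguishable at this position. Hydrogen in place of cyclopropyl on an amide-type nitrogen gives a 2.9-fold higher number from compound 1 to compound 4 (0.46 log units; beyond the scatter) and thus shows, in this single pair, a modest but readable loss of binding when the cyclopropyl is removed. No measurement here explains either step.

From the compounds shown here alone, whether a longer chain, such as butyl, or a chain ending in an amine would also leave binding unchanged at the saturated chain carbon remains open. Going by these compounds, it is also open whether a larger group on the amide-type nitrogen, such as cyclohexyl, would bind more tightly than cyclopropyl.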